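Removing the amide methyl: from compound 1 to compound 4

The source may report more compounds than this note shows. Statements on the series, on what has been measured and on what is new or still open speak of the compounds shown alone.

Compound 1 `Cc1cc(Cl)ccc1C(=O)N(C)c1cccnc1` is a small amide in which a substituted benzene carries a carbonyl joined through a nitrogen to a pyridine. Tested in an ADME assay on cells for inhibition of cytochrome P450 11B1, mitochondrial (Homo sapiens), read by HTRF (on this read-out higher numbers stand for weaker inhibition and lower numbers for stronger inhibition), compound 1 gives > 3000 nM. Among the measured compounds shown here, that figure is a limit of the assay rather than a number, and compound 1 is the one compound that sits at the limit of > 3000 nM in this assay, at which 1 of the 3 values shown sits. Two larger compounds from the same study give numbers instead. Compound 2 `CC(=O)N[C@H]1CCCc2c1cncc2N1Cc2cc(Cl)ccc2C1=O` gives 39600 nM in this assay, and compound 3 `CCC(=O)N[C@@H]1CCCc2c1cncc2N1CCc2cc(Cl)ccc2C1=O` gives 3330 nM. Both values show weak inhibition; neither shares the core of compound 1.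

Compound 4 `Cc1cc(Cl)ccc1C(=O)Nc1cccnc1` differs from compound 1 in one place only: hydrogen in place of methyl on an amide-type nitrogen. For the measured compounds named here, no measured pair in this set makes that same change, and the size of the step has to be guessed. With compound 1 already at a limit, a step toward weaker inhibition would stay invisible, and only a move toward stronger inhibition could yield a number. My expectation for compound 4 is a value near the limit, 3000 nM, within the range 800 nM to 12000 nM. The step from compound 1 to compound 4 that this estimate implies is a number no higher from compound 1 to compound 4 (the limit leaves the size open), expected to be none beyond the scatter.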

Compound 4, half-maximal inhibitory concentration: > 3000 nM
Compound 4: a limit, no number; the forecaster's own chance of this, stated with the estimate: 50%; the middle value lies on the limit itself.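

In this assay compound 4 gives > 3000 nM, a limit and not a number. Compound 1 stands at a limit too, so no step can be read between compound 1 and compound 4: the limit of > 3000 nM in this assay, at which 2 of the 4 values shown sit.

The compounds shown leave open how strongly either compound inhibits, and whether hydrogen in place of methyl on the amide-type nitrogen makes any difference.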